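Swapping an amino linker for an ether in compound 2

This account rests on a few compounds, and the source may have more. Where it says the series, first, only, none or still open, it means among the compounds named here.

Of the compounds shown here, three have been measured in an in vitro assay on 293-EBNA cells for binding affinity to corticotropin-releasing factor receptor 1 (Homo sapiens); on this read-out lower numbers stand for stronger inhibition and higher numbers for weaker inhibition. Compound 1 `CCCC(CCC)Nc1nc(C)nc2c1nnn2-c1ccc(Br)cc1Br` gives 0.8 nM, compound 2 `COCC(COC)Nc1nc(C)nc2c1nnn2-c1ccc(C(C)C)cc1Br` gives 10.3 nM, and compound 3 `CCCCN(CC)c1nc(C)nc2c1nc(-c1ccccc1)n2-c1c(Cl)cc(OC)cc1OC` gives 133 nM. Compound 2 therefore sits in the middle of these three numbers, beyond the scatter from both compound 1 and compound 3. Compound 4 `COCC(COC)Oc1nc(C)nc2c1nnn2-c1ccc(C(C)C)cc1Br` has not been measured. It differs from compound 2 by one change: a group of 8 heavy atoms (5 carbon, 3 oxygen; no ring) in place of a group of 8 heavy atoms (5 carbon, 1 nitrogen, 2 oxygen; no ring), on an aromatic carbon. The group entering has no hydrogen-bond donor, whereas the group leaving has one. Going by the values given here, no measured pair shows this change, so the expectation rests on judgement alone: a step toward weaker binding of roughly a 4.9-fold higher number from compound 2 to compound 4 (0.69 log units; beyond the scatter) is expected. Compound 4 is estimated at 50 nM, between 15 nM and 200 nM.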

Compound 4, inhibition constant: 7.1 nM
Compound 4: the middle estimate sits 7.0-fold (0.85 log units) above what was measured, outside the stated range (below it).
By their numbers in this assay, from the lowest: compound 1; then compounds 4 and 2 (each within the scatter of the next); then compound 3.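

In this assay, replacing the (2-methoxy-1-(methoxymethyl)ethyl)amino group with its oxygen-linked counterpart gives a 1.5-fold lower number from compound 2 to compound 4 (0.16 log units; within the scatter) on this aromatic carbon next to the ring nitrogen. In this pair, then, losing the hydrogen-bond donor leaves binding indistinguishable, so the donor is not needed here for a value in this range. Nothing measured here bears on why this is so.

Open, from the compounds shown here alone, is whether a sulfur atom or a methylene group in place of this oxygen would also hold binding. Also open, going by these compounds, is whether the same swap would hold on the core of compound 1, with its longer chain and second bromine.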